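The source may hold more compounds than are shown below. What is called first, only, known or untested is meant among the compounds shown, and "the series" means these compounds.

Measured compounds in an assay on isolated protein (blood) for antagonist activity at C-C chemokine receptor type 4 (Homo sapiens), read by flow cytometry, with a stated time of 30 min; a lower number here means tighter binding, a higher number weaker binding:

compound 1 `CC(=O)NCc1cccc(Cn2nc(NS(=O)(=O)c3ccc(Cl)s3)c3c(CO)cccc32)c1` — 1000 nM
compound 2 `CC(=O)NCc1cccc(Cn2nc(NS(=O)(=O)c3ccc(Cl)s3)c3c(C(C)O)cccc32)c1` — 501 nM
compound 3 `COc1cccc2c1c(NS(=O)(=O)c1ccc(Cl)s1)nn2Cc1cccc(CNC(=O)C2COC2)c1` — 1000 nM

Compound 3 stands level with compound 1 at the digits shown; the value of compound 2 sits apart from both only within the usual scatter, so the three measured compounds are, in effect, indistinguishable in this assay.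

Compound 4 `CN[C@H](C)C(=O)NCc1cccc(Cn2nc(NS(=O)(=O)c3ccc(Cl)s3)c3c(OC)cccc32)c1` is derived from compound 3 by 1-(methylamino)ethyl in place of oxetan-3-yl on a carbonyl carbon. Within the data shown here, the only measured step, a 2.0-fold lower number from compound 1 to compound 2 (0.30 log units; within the scatter), concerns a different part of the molecule, the side chain on the shared core, and is itself within the scatter; there is no measured step that alters the amide cap on the benzylamine arm, so nothing here bears directly on the change from compound 3 to compound 4. Among the measured compounds shown here, with the three measured values bunched together and no informative precedent, no movement beyond the scatter is expected.

Compound 4 is therefore estimated at 1000 nM in this assay, with a range of 300 nM to 3000 nM, which corresponds to an expected step of no change at the digits printed from compound 3 to compound 4 (within the scatter).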

Compound 4, dissociation constant: 200 nM
Estimate against measurement, compound 4: 5.0-fold (0.70 log units) above; the measured number lies below the stated range.
By their numbers in this assay, from the lowest: compound 4; then compounds 2, 1 and 3 (each within the scatter of the next).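

In this assay, among these compounds, the group on the carbonyl carbon whose other neighbour is the amide-type nitrogen is the first place where a change moves the number beyond the scatter, with a 5.0-fold lower number from compound 3 to compound 4 (0.70 log units; beyond the scatter) as 1-(methylamino)ethyl replaces oxetan-3-yl. The exchange removes the four-membered non-aromatic ring, puts nitrogen where oxygen stood, and adds a hydrogen-bond donor and a defined stereocentre, so the step belongs to the whole group and not to any one of these features. Nothing measured here accounts for the step.

Still open, going by these compounds, is how a 1-hydroxyethyl group, a 1-(dimethylamino)ethyl group or the opposite stereocentre would read on the same carbonyl carbon. Also open, on these data alone, is whether the same exchange would give a similar step on the shared core carrying the hydroxymethyl group of compound 1.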